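Nitrophenyl variant of the salicylaldimine thiadiazole–oxadiazole series

The source may report more compounds than this note shows. Statements on the series, on what has been measured and on what is new or still open speak of the compounds shown alone.

Three compounds share one core and differ only in the aryl group on the oxadiazole carbon. Compound 1 `Oc1ccccc1/C=N/c1nnc(SCc2nnc(-c3ccccc3Br)o2)s1` gives 7150 nM in a functional assay on A549 cells (Homo sapiens) for inhibition, read by CCK-8 assay; on this read-out lower numbers stand for stronger inhibition and higher numbers for weaker inhibition. Compound 2 `Oc1ccccc1/C=N/c1nnc(SCc2nnc(-c3ccc(Br)cc3)o2)s1` gives 20000 nM in this assay, and compound 3 `Cc1ccc(-c2nnc(CSc3nnc(/N=C/c4ccccc4O)s3)o2)cc1` gives 22000 nM in this assay. Compound 2 holds the second highest of the three numbers; its nearest neighbour is compound 3, which it cannot be separated from, while compound 1 sits lower by a 2.8-fold higher number from compound 1 to compound 2 (0.45 log units; beyond the scatter).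

The unmeasured compound 4 `O=[N+]([O-])c1cccc(-c2nnc(CSc3nnc(/N=C/c4ccccc4O)s3)o2)c1` differs from compound 2 by 3-nitrophenyl in place of 4-bromophenyl on an aromatic carbon.

For the measured compounds named here, two measured steps bear on this. Moving the bromine on the phenyl ring gave a 2.8-fold higher number from compound 1 to compound 2 (0.45 log units; beyond the scatter), and swapping the substituent at one position gave a 1.1-fold higher number from compound 2 to compound 3 (0.04 log units; within the scatter). Nothing tests a nitro group or a 3-substituted phenyl directly. Given the small exchange step from compound 2 to compound 3, compound 4 is expected to land near compound 2, with an expected step of a 1.1-fold lower number from compound 2 to compound 4 (0.05 log units; within the scatter) in this assay. The estimate for compound 4 is 18000 nM, within 6000 nM to 50000 nM.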

Compound 4, half-maximal inhibitory concentration: 36900 nM
The estimate for compound 4 lay 2.1-fold (0.31 log units) below the measured number; measured number inside the range.
By their numbers in this assay, from the lowest: compound 1; then compounds 2, 3 and 4 (each within the scatter of the next).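

In this assay, 3-nitrophenyl at this position cannot be separated from 4-bromophenyl (a 1.8-fold higher number from compound 2 to compound 4 (0.27 log units; within the scatter)) or from 4-methylphenyl (a 1.7-fold higher number from compound 3 to compound 4 (0.22 log units; within the scatter)), so a group with a different heavy-atom count and with hydrogen-bond acceptors still falls in the same band as compounds 2 and 3. For the compounds shown here, compound 1, with 2-bromophenyl, remains the only clear outlier and holds the lowest number of the four, and the widest step so far (a 5.2-fold higher number from compound 1 to compound 4 (0.71 log units; beyond the scatter)) lies beyond the scatter. No measurement bears on what lies behind these numbers.

As far as these compounds go, whether the lower number of compound 1 belongs to the bromine or to its placement on the phenyl ring stays open, as no other group here shares that placement. An amine or a carboxylic acid on the phenyl ring, or an unsubstituted phenyl, would test whether this band extends beyond the groups shown.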